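The compounds below may be only part of what the source reports. "The series", "measured", "known", "first", "only" and "open" are said of these compounds alone.

Measured so far in an in vivo ADME assay on the whole organism (strain beagle) for pharmacokinetics, with Canis familiaris (Canis lupus familiaris) as the target, at a dose of 0.5 mg/kg by the oral route; a lower number here means that a smaller share of the oral dose reaches the circulation, a higher number that a larger share of the oral dose reaches the circulation:

Compound 1, `O=C(O)CCNC(=O)c1ccc(CN(c2ccc(Cl)cc2)c2nc(-c3ccc(OC(F)(F)F)cc3)cs2)cc1`, gives 71%.
Compound 2, `O=C(O)CCNC(=O)c1ccc(CN(c2ccc3c(c2)CCCC3)c2nc(-c3ccc(Cl)c(Cl)c3)cs2)cc1`, gives 92%.

Compound 1 holds the lower of the two numbers in this assay. Compound 2 reaches a number that stands well above it, and the gap between the two lies beyond the usual scatter; the two compounds differ in several places at once, so nothing more is read from that pair.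

The step now followed leads from compound 1 to compound 3, `O=C(O)CCNC(=O)c1ccc(CN(c2ccc(Cl)cc2)c2nc(-c3ccc(C(F)(F)F)cc3)cs2)cc1`, which has not yet been measured in this assay. The change is small and confined to one position on the outer aromatic ring: trifluoromethyl in place of trifluoromethoxy on an aromatic carbon. The shared core, the acid-bearing side chain and the chlorine-bearing ring of compound 1 are kept as they are.

Within the data shown here, no measured pair shows this exact change, so the expectation rests on compound 1 alone. Because compound 1 already gives 71%, compound 3 is expected to land close to it, with a step of a number 1 percentage points lower from compound 1 to compound 3 (within the scatter) that stays within the scatter. For compound 3 the estimate in this assay is 70%, with a range from 52% to 88%.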

Compound 3, oral bioavailability: 16%
Beside the measured number, compound 3's estimate is 54 percentage points above it; the whole stated range lies above it.
By their numbers in this assay, from the lowest: compound 3; then compound 1; then compound 2.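

Trifluoromethyl in place of trifluoromethoxy on an aromatic carbon, para to a large group, brings a number 55 percentage points lower from compound 1 to compound 3 (beyond the scatter) in this assay. The earlier compounds shown here could not show this, since compound 1 and compound 2 differ in several places at once; this single-place pair shows that the outer ring position strongly affects the result, even though the two groups differ only by the oxygen of trifluoromethoxy. No measurement at hand says what lies behind this step, so the reason for it remains open.

Since this is a single pair, the compounds shown leave open whether the outcome follows from the loss of that oxygen or is specific to these two groups, and whether a methoxy group, an ethoxy chain or a nitrile in the same place would give a number closer to that of compound 1 or to that of compound 3. They also leave open whether the same exchange would carry a step of this size with an amine or a fluorine in place of the chlorine on the other ring.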